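Replacing the Nitrogen Group on a Weak Phenoxy Compound

The source may hold more compounds than are shown below. What is called first, only, known or untested is meant among the compounds shown, and "the series" means these compounds.

In a functional assay on PANC-1 cells (Homo sapiens) for inhibition, read by XTT assay, with a stated time of 72 h (on this read-out higher numbers stand for weaker inhibition and lower numbers for stronger inhibition), compound 2 (`CC(C)(C)OC(=O)N1CCC[C@H]1COCCCCCC/C=C/c1ccc(Oc2ccccc2)cc1`) gives 63300 nM as the only true number shown. Compound 1 (`CC(C)(C)OC(=O)N1CCC[C@H]1COCCCCCC/C=C/c1ccc(-c2ccccc2)cc1`) gives > 100000 nM as a limit of the assay. Compound 3 (`CCCCCCCC/C=C\CCCCCCCCOC[C@@H]1CCCN1[S+]([O-])c1ccc(C)cc1`) gives > 100000 nM as a limit as well. Going by the values given here, the only measured step of an at least 1.5-fold lower number from compound 1 to compound 2 (0.19 log units; that floor lies within the scatter) concerns phenoxy in place of phenyl on an aromatic carbon and leaves the group on the nitrogen untouched.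

Among the compounds with values here, compound 4 (`Cc1ccc([S+]([O-])N2CCC[C@H]2COCCCCCC/C=C/c2ccc(Oc3ccccc3)cc2)cc1`) departs from compound 2 by a group of 9 heavy atoms (7 carbon, 1 oxygen, 1 sulfur; one six-membered aromatic ring of carbon only) in place of a group of 7 heavy atoms (5 carbon, 2 oxygen; no ring), on an amine nitrogen in a ring and no measured step covers that change. Compound 3 carries the same entering group on a different chain and gives > 100000 nM as a limit, so in this assay no step beyond the scatter is expected, with a slight lean towards weaker inhibition. The expected size of a 1.1-fold higher number from compound 2 to compound 4 (0.04 log units; within the scatter) is small, an estimate that stays within the scatter. For compound 4 the estimated value is 70000 nM with an expected range from 30000 nM to 100000 nM in this read-out.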

Compound 4, half-maximal inhibitory concentration: 60000 nM
Compound 4: the middle estimate sits 1.2-fold (0.07 log units) above what was measured; measured number inside the range.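

At the amine nitrogen in a ring, placing the sulfur-bearing group with its six-membered aromatic ring in place of tert-butoxycarbonyl gives a 1.1-fold lower number from compound 2 to compound 4 (0.02 log units; within the scatter), so the two groups cannot be told apart in this assay. Compound 3 carries the same sulfur-bearing group on a different chain and gives > 100000 nM, which is a limit of the assay. Going by these compounds alone, compound 4 supplies the first true number for this group on the nitrogen, but it remains a weak reading close to that limit: the limit of > 100000 nM in this assay, at which 2 of the 4 values shown sit.

On these data alone, what a free amine or an acetyl group on this nitrogen would do remains open. Also open, as far as these compounds go, is how the sulfur-bearing group would read on the phenyl-bearing chain of compound 1, or how a longer chain would change the picture.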